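A Phenoxy Group Returns, Now Carrying Dimethylamino

The compounds below may be only part of what the source reports. "The series", "measured", "known", "first", "only" and "open" are said of these compounds alone.

Measured so far in a physicochemical assay for acid dissociation:
compound 1 `COc1cccc(CNCCCNc2ccnc3cc(Oc4ccc(F)cc4)ccc23)c1O` gives 9.28;
compound 2 `COc1cccc(CNCCCNc2ccnc3cc(CCC(C)C)ccc23)c1O` gives 9.47;
compound 3 `COc1cccc(CNCCCNc2ccnc3cc(Cc4ccc(F)cc4)ccc23)c1O` gives 9.47.

Compound 3 shares the top position with compound 2 at the digits shown, and the two stand within the scatter of each other. The remaining measured step is a number 0.19 log units higher from compound 1 to compound 3 (within the scatter), so all three measured compounds lie within the scatter of one another.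

Compound 4 `COc1cccc(CNCCCNc2ccnc3cc(Oc4cccc(N(C)C)c4)ccc23)c1O` is the next step. It differs from compound 3 in one place: 3-(dimethylamino)phenoxy in place of 4-fluorobenzyl on an aromatic carbon.

Two measured steps speak to this change. The exchange of a 4-fluorophenoxy group for other groups on the same aromatic carbon gave a number 0.19 log units higher from compound 1 to compound 2 (within the scatter) and a number 0.19 log units higher from compound 1 to compound 3 (within the scatter), and the exchange between isobutyl and 4-fluorophenyl gave no change at the digits printed from compound 2 to compound 3 (within the scatter). Every change at this position has so far left this assay unmoved beyond the scatter. Compound 4 brings a phenoxy group back to that carbon, as in compound 1, so the expected step is a number 0.12 log units lower from compound 3 to compound 4 (within the scatter), at most a drift toward the value of compound 1 and nothing beyond the scatter.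

Compound 4 is therefore expected to give 9.35, between 9.1 and 9.6.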

Compound 4, acid dissociation constant: 9.28
Estimate against measurement, compound 4: 0.07 log units above, and the stated range covers the measured number.
By their numbers in this assay, from the lowest: compounds 1, 4, 2 and 3 (each within the scatter of the next).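

In this assay, placing a 3-(dimethylamino)phenoxy group on this aromatic carbon gives a number 0.19 log units lower from compound 3 to compound 4 (within the scatter) and a number 0.19 log units lower from compound 2 to compound 4 (within the scatter), so a group counted with two hydrogen-bond acceptors, where 4-fluorobenzyl has none, still leaves the reading inside the usual scatter. Exchanging only the ring on the oxygen, 3-(dimethylamino)phenyl in place of 4-fluorophenyl, gives no change at the digits printed from compound 1 to compound 4 (within the scatter), and so across all four compounds, with no exception among them, the group on this carbon has not moved the number beyond the scatter, even with a nitrogen now in that group. Nothing available here gives a reason for this flat picture.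

Still open, going by these compounds, is whether the same holds for a group of a different kind on the phenoxy ring, such as a carboxylic acid or a primary amine, or for a small methoxy group on the same aromatic carbon. On these data alone, the rest of the molecule is identical in all four compounds, so what a change elsewhere would do to this number also remains unknown.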